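Cyanophenyl sulfone: expected clearance from three measured analogues

The source may hold more compounds than are shown below. What is called first, only, known or untested is meant among the compounds shown, and "the series" means these compounds.

Measured so far:
compound 1 `O=S(=O)(c1ccc(F)cc1)c1cnc2cc(F)ccc2c1-c1cccc(F)c1`: 0.95 mL/min
compound 2 `O=S(=O)(c1cc(F)cc(F)c1)c1cnc2cc(F)ccc2c1-c1cccc(F)c1`: 0.06 mL/min
compound 3 `O=S(=O)(c1ccc(F)c(Cl)c1)c1cnc2cc(F)ccc2c1-c1cccc(F)c1`: 0.25 mL/min

In an ADME assay on microsomes from liver (Homo sapiens) for metabolic stability, tested at 2.5 uM (on this read-out lower numbers stand for slow clearance and higher numbers for fast clearance), compound 3 gives 0.25 mL/min. It stands second highest of the three numbers, with compound 1 nearest and compound 2 furthest away: a 3.8-fold lower number from compound 1 to compound 3 (0.58 log units; beyond the scatter) and a 4.2-fold higher number from compound 2 to compound 3 (0.62 log units; beyond the scatter), both beyond the scatter.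

Compound 4 `N#Cc1cccc(S(=O)(=O)c2cnc3cc(F)ccc3c2-c2cccc(F)c2)c1` differs from compound 3 in one place: 3-cyanophenyl in place of 3-chloro-4-fluorophenyl on a sulfonyl sulfur. For the measured compounds named here, no measured step involves a nitrile, so the bearing steps are indirect. They show that the group on the sulfonyl sulfur moves this assay strongly: a 16-fold lower number from compound 1 to compound 2 (1.20 log units; beyond the scatter), a large step, and the modest steps of a 3.8-fold lower number from compound 1 to compound 3 (0.58 log units; beyond the scatter) and a 4.2-fold higher number from compound 2 to compound 3 (0.62 log units; beyond the scatter). Replacing the whole ring, rather than one atom on it, may move the number in either direction by a modest or large amount. Because compound 1 gives 0.95 mL/min and compound 3 gives 0.25 mL/min, compound 4 is expected to land between or around these two numbers, with a modest rise considered most likely, as a 1.6-fold higher number from compound 3 to compound 4 (0.20 log units; within the scatter). Compound 4 is estimated at 0.4 mL/min, within a range of 0.12 mL/min to 1.3 mL/min.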

Compound 4, intrinsic clearance in a liver preparation (reported as CLH), per the amount of preparation that the assay uses: 0.78 mL/min
Compound 4: the middle estimate sits 2.0-fold (0.29 log units) below what was measured; measured number inside the range.
By their numbers in this assay, from the lowest: compound 2; then compound 3; then compounds 4 and 1 (each within the scatter of the next).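

In this assay the 3-cyanophenyl ring on the sulfonyl sulfur separates clearly from both rings that carry two halogens, with a 3.1-fold higher number from compound 3 to compound 4 (0.49 log units; beyond the scatter) and a 13-fold higher number from compound 2 to compound 4 (1.11 log units; beyond the scatter). It cannot be told apart from the 4-fluorophenyl ring, with a 1.2-fold lower number from compound 1 to compound 4 (0.09 log units; within the scatter), so across these four compounds the two rings with a single group, in compound 1 and compound 4, stand apart from the two rings with two halogens, in compound 2 and compound 3, and none of the four goes against this. Nothing measured here explains this split.

The compounds shown do not tell whether the nitrile itself matters or whether the split follows the number of groups on the ring, and a ring bearing both a nitrile and a fluorine on the sulfonyl sulfur would separate the two readings. They also leave open how this read-out responds to a methoxy group, an amine or a carboxylic acid on that ring, or to a pyridine ring in place of the phenyl ring.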